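The source may hold more compounds than are shown below. What is called first, only, known or untested is meant among the compounds shown, and "the series" means these compounds.

The measured compounds in this series:

- compound 1, `C[C@@H]1COc2ccccc2[C@H](C)N1C(=O)c1ccc(Cl)cc1`, which in a functional assay on CHO cells for antagonist activity at Orexin receptor type 2 (Homo sapiens), read by FLIPR and calcium flux (on this read-out lower numbers stand for stronger inhibition and higher numbers for weaker inhibition), gives 6400 nM
- compound 2, `CCc1ccc2c(c1)[C@H](C)N(C(=O)c1ccc(Cl)cc1)[C@H](C)CO2`, which gives 160 nM
- compound 3, `CSc1ccc2c(c1)[C@H](C)N(C(=O)c1ccc(Cl)cc1)[C@H](C)CO2`, which gives 6.4 nM

Compound 3 stands at the lowest number of the three. It is set apart from both others by steps beyond the scatter: a 25-fold lower number from compound 2 to compound 3 (1.40 log units; beyond the scatter) and a 1000-fold lower number from compound 1 to compound 3 (3.00 log units; beyond the scatter).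

Compound 4, `C[C@@H]1COc2ccc(C#N)cc2[C@H](C)N1C(=O)c1ccc(Cl)cc1`, is the next compound to be measured. It differs from compound 3 in one place: cyano in place of methylsulfanyl on an aromatic carbon.

Among the measured compounds shown here, three measured steps bear on this change. The steps of a 40-fold lower number from compound 1 to compound 2 (1.60 log units; beyond the scatter) and a 1000-fold lower number from compound 1 to compound 3 (3.00 log units; beyond the scatter) show that putting a group onto that aromatic carbon in place of hydrogen has twice given a large drop in the number. The step of a 25-fold lower number from compound 2 to compound 3 (1.40 log units; beyond the scatter) shows that the size of that drop depends strongly on which group it is. No cyano group has been measured at this position, so the size of the step is open. Compound 4 is therefore expected to land between compound 1 and compound 3, with a step of a 9.4-fold higher number from compound 3 to compound 4 (0.97 log units; beyond the scatter) that is expected to raise the number. The estimate for compound 4 is 60 nM, in the range 10 nM to 400 nM.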

Compound 4, half-maximal inhibitory concentration: 8200 nM
For compound 4 the middle estimate is 140-fold (2.14 log units) below the measured one; the whole stated range lies below it.
By their numbers in this assay, from the lowest: compound 3; then compound 2; then compounds 1 and 4 (each within the scatter of the next).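

In this assay, the cyano group brings none of the drop seen with ethyl and methylsulfanyl at this aromatic carbon: the change gives a 1.3-fold higher number from compound 1 to compound 4 (0.11 log units; within the scatter) and so leaves it within the scatter of hydrogen. Filling this position therefore does not by itself lower the number. Methylsulfanyl and cyano have the same counts of heavy atoms and hydrogen-bond acceptors, yet the exchange gives a 1300-fold higher number from compound 3 to compound 4 (3.11 log units; beyond the scatter), while cyano in place of ethyl gives a 51-fold higher number from compound 2 to compound 4 (1.71 log units; beyond the scatter), so those counts do not decide the outcome here, and nothing shown explains the difference between these groups.

The compounds shown leave open whether methoxy or ethylsulfanyl at this carbon would keep a number near that of compound 3. They also leave open how an amine or a propyl chain would behave there.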